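Nitro to methoxy on the imine-bound aryl ring

A few compounds are considered here, and "the series" means these few. Any claim that something is new, unique, unknown or untested is made for them only; others in the source may bear on it.

The series shares one core, seen in compound 2 `COc1cc(C2CC(c3ccc([N+](=O)[O-])cc3)=NN2C(C)=O)ccc1OCc1cn(Cc2ccc([N+](=O)[O-])cc2)nn1`. In a functional assay on COLO 205 cells (Homo sapiens) for inhibition, read by sulforhodamine B assay, tested at 100 uM (a lower number here means less inhibition of growth, a higher number more inhibition of growth at the concentration tested), compound 2 gives 85%, the second highest of the three numbers. Compound 3 `COc1cc(C2CC(c3cc(OC)c(OC)c(OC)c3)=NN2C(C)=O)ccc1OCc1cn(Cc2ccc([N+](=O)[O-])cc2)nn1` gives 99% in this assay, and compound 1 `COc1ccc(C2CC(c3ccc(OCc4cn(Cc5ccc([N+](=O)[O-])cc5)nn4)cc3)=NN2C(C)=O)cc1` gives 37%. For the measured compounds named here, the one step measured in one place, a number 14 percentage points higher from compound 2 to compound 3 (beyond the scatter), placed 3,4,5-trimethoxyphenyl for 4-nitrophenyl on the carbon double-bonded to nitrogen. Compound 4 `COc1ccc(C2=NN(C(C)=O)C(c3ccc(OCc4cn(Cc5ccc([N+](=O)[O-])cc5)nn4)c(OC)c3)C2)cc1` is reached from compound 2 by methoxy in place of nitro on an aromatic carbon, on the same aryl ring. Going by the values given here, that step is the only one bearing on this change; compound 4 carries a single methoxy where compound 3 carried three, so a smaller rise, or none beyond the scatter, is expected, a number 3 percentage points higher from compound 2 to compound 4 (within the scatter). Compound 4 is therefore expected to give 88% in this assay, between 72% and 99%.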

Compound 4, percent growth inhibition at one concentration: 75%
Beside the measured number, compound 4's estimate is 13 percentage points above it; measured number inside the range.
By their numbers in this assay, from the lowest: compound 1; then compounds 4 and 2 (each within the scatter of the next); then compound 3.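

In this assay, the step at this position reads a number 10 percentage points lower from compound 2 to compound 4 (within the scatter), so 4-nitrophenyl and 4-methoxyphenyl are not told apart here. The second step reads a number 24 percentage points lower from compound 3 to compound 4 (beyond the scatter), which shows that a single methoxy does not carry what 3,4,5-trimethoxyphenyl shows at this position. The data at hand offer no explanation for either step. On these data alone, what stays open is how an amine or a hydroxyl on this ring would read, and whether a ring with two methoxy groups would sit with compound 4 or with compound 3.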